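The source may report more compounds than this note shows. Statements on the series, on what has been measured and on what is new or still open speak of the compounds shown alone.

In a functional assay on HT-29 cells (Homo sapiens) for cytotoxicity, read by MTT assay, with a stated time of 24 h, tested at 6.4 ug/mL (on this read-out lower numbers stand for a weaker effect and higher numbers for a stronger effect at the one concentration tested), compound 1 `Cn1c(-c2ccc(NC(=O)CSc3nc4ccccc4o3)cc2)nc(-c2ccccc2)c1-c1ccccc1` gives 44.9%, the highest of the three numbers measured. Compound 2 `Cn1c(-c2ccc(NC(=O)CSc3nc4cc(Cl)ccc4o3)cc2)nc(-c2ccccc2)c1-c1ccccc1` gives 29.4% and compound 3 `Cn1c(-c2ccc(NC(=O)CSC3=NCCS3)cc2)nc(-c2ccccc2)c1-c1ccccc1` gives 31%; the two steps from compound 1 were a number 15.5 percentage points lower from compound 1 to compound 2 (beyond the scatter) and a number 13.9 percentage points lower from compound 1 to compound 3 (beyond the scatter). Compound 4 `CN1CCN(CC(=O)Nc2ccc(-c3nc(-c4ccccc4)c(-c4ccccc4)n3C)cc2)CC1` differs from compound 1 by 4-methylpiperazin-1-yl in place of (1,3-benzoxazol-2-yl)sulfanyl on a saturated chain carbon bound to a carbonyl carbon. The step to compound 3 bears most directly on it, since there too the group on the sulfur was replaced, and every change made at this part of compound 1 so far has lowered the read-out modestly. A modest drop is therefore expected, a number 14.9 percentage points lower from compound 1 to compound 4 (beyond the scatter). Compound 4 is estimated at 30%, with a range from 15% to 45%.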

Compound 4, a percentage reported as activity, at one concentration (the size of the read-out at that concentration, not a potency): 28.8%
Compound 4: middle estimate off by 1.2 percentage points, on the high side, within the range that was stated.
By their numbers in this assay, from the lowest: compounds 4, 2 and 3 (each within the scatter of the next); then compound 1.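

In this assay, 4-methylpiperazin-1-yl on the saturated chain carbon bound to a carbonyl carbon gives a drop of the same kind as the earlier changes, a number 16.1 percentage points lower from compound 1 to compound 4 (beyond the scatter), so the drop also appears with an entering group that holds no sulfur. Compound 4 cannot be told apart from the other two changed compounds, with a number 2.2 percentage points lower from compound 3 to compound 4 (within the scatter) and a number 0.6 percentage points lower from compound 2 to compound 4 (within the scatter), which leaves only compound 1 standing apart among these four. No measured evidence explains these results. From the compounds shown here alone, whether morpholine or an open-chain dimethylamino group at this carbon would give a similar number remains open.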